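The compounds below may be only part of what the source reports. "The series", "measured", "known", "first", "only" and "open" are said of these compounds alone.

Measured compounds:
- compound 1, `COc1cc(C)c(S(=O)(=O)N(C)CCOCC(=O)N2CCC(C(C)(C)CN(C)C)CC2)c(C)c1`: 10 nM
- compound 2, `COc1cc(C)c(S(=O)(=O)N(C)CCOCC(=O)N2CCN(CCCN(C)C)CC2)c(C)c1`: 5.8 nM

Both compounds were tested in an assay on HEK293 cells for displacement of a labelled ligand from B1 bradykinin receptor (Homo sapiens), read by scintillation counting; on this read-out higher numbers stand for weaker inhibition and lower numbers for stronger inhibition. Compound 1 gives 10 nM, the higher of the two numbers measured, while compound 2 gives 5.8 nM; the gap between them lies within the usual scatter of this assay, so the two values cannot be told apart with confidence.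

Compound 3, `COc1cc(C)c(S(=O)(=O)N(C)CCOCC(=O)N2CCC(CN3CCN(C)CC3)CC2)c(C)c1`, has not yet been measured. It differs from compound 1 in one place: (4-methylpiperazin-1-yl)methyl in place of 1-((dimethylamino)methyl)-1-methylethyl on a saturated ring carbon. The group that leaves and the group that enters each carry a basic nitrogen and a similar count of heavy atoms, but the entering group brings a six-membered non-aromatic ring with 2 hetero atoms where the leaving group had no ring.

For the measured compounds named here, no pair of measured compounds differing in one place is available, so nothing in these data shows how such a change plays out. The step from compound 1 to compound 3 is therefore expected to be small, most likely toward a weaker result, and possibly no larger than the scatter: a 1.5-fold higher number from compound 1 to compound 3 (0.18 log units; within the scatter). Compound 3 is estimated to give 15 nM in this assay, with a plausible range from 4 nM to 60 nM.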

Compound 3, inhibition constant: 4.7 nM
Beside the measured number, compound 3's estimate is 3.2-fold (0.50 log units) above it, within the range that was stated.
By their numbers in this assay, from the lowest: compounds 3, 2 and 1 (each within the scatter of the next, the first and the last beyond it).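

In this assay, replacing 1-((dimethylamino)methyl)-1-methylethyl with (4-methylpiperazin-1-yl)methyl on a saturated ring carbon gives a 2.1-fold lower number from compound 1 to compound 3 (0.33 log units; beyond the scatter), a modest step. For the compounds shown here, this is the first pair here that differs in one place, and it shows that this ring carbon, three ring bonds from the ring nitrogen, can carry a six-membered non-aromatic ring with 2 hetero atoms instead of an open branched group, with no loss of inhibition on this read-out. Nothing available explains why the number falls with this change.

Going by these compounds alone, with only this one change at this carbon, the result cannot be assigned to a single feature of the entering group, such as the ring itself, the second ring nitrogen or the methyl group on that nitrogen. Going by these compounds, whether piperidin-1-ylmethyl, morpholin-4-ylmethyl or piperazin-1-ylmethyl, which has no methyl group on the ring nitrogen, would match (4-methylpiperazin-1-yl)methyl stays open, as does whether a longer chain linking the ring to this carbon would be accepted.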